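The compounds below may be only part of what the source reports. "The series", "measured", "known", "first", "only" and "open" are said of these compounds alone.

Measured so far:
Compound 1 `Cc1ccc(S(=O)(=O)N[C@@H](CC(=O)NC(C)(C)C)C(=O)NCCNC(=O)c2ccccc2Cl)cc1`. In an ADME assay on Karpas-1106P cells (Homo sapiens) for cytotoxicity (a higher number here means that more compound is needed for the effect, a lower number that less compound is needed), compound 1 gives > 11100 nM, a limit of the assay.
Compound 2 `Cc1ccc(S(=O)(=O)N[C@@H](CC(=O)NC(C)(C)C)C(=O)NCCNC(=O)c2cccc(C#N)c2)cc1`. In this assay compound 2 gives > 11100 nM, also a limit.

Compound 2 thus stands at the limit of > 11100 nM in this assay, at which 2 of the 2 values shown sit, with no number of its own. The step that the two limits leave unreadable from compound 1 to compound 2 is unreadable, both ends being limits. Compound 3 `Cc1ccc(S(=O)(=O)N[C@@H](CC(=O)NC(C)(C)C)C(=O)NCCNC(=O)c2ccccc2O)cc1` differs from compound 2 by 2-hydroxyphenyl in place of 3-cyanophenyl on a carbonyl carbon. Among the compounds with values here, no measured step gives a readable size for a change of this kind, so no shift beyond the scatter is expected in this assay, and a further limit is the likeliest outcome. Compound 3 is expected at 15000 nM, within 5000 nM to 50000 nM. The expected step is a step that the limit leaves unreadable from compound 2 to compound 3.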

Compound 3, half-maximal effective concentration: > 11100 nM
Compound 3: no number, only a limit; the forecaster's own chance of this, stated with the estimate: 75%; the middle value lies beyond the limit too.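

Within the data shown here, no step among compounds 1, 2 and 3 can be read in this assay, as all three give the same assay limit: the limit of > 11100 nM in this assay, at which 3 of the 3 values shown sit.
From the compounds shown here alone, it remains open whether any change to the shared core gives a readable number in this assay at all.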